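Fluoro in place of methoxy in compound 2

A few compounds are considered here, and "the series" means these few. Any claim that something is new, unique, unknown or untested is made for them only; others in the source may bear on it.

In a functional assay on MDA-MB-453 cells (Homo sapiens) for cytotoxicity, read by MTT assay, with a stated time of 48 h (on this read-out higher numbers stand for weaker inhibition and lower numbers for stronger inhibition), compound 2 (`COc1ccc(-c2nnc(COc3ccc(C#N)c(F)c3)o2)cc1`) gives 45500 nM and compound 1 (`COc1cc(C#N)ccc1OCc1nnc(-c2ccc(C)cc2)o1`) gives 38400 nM and the two values lie within the scatter of each other. Compound 3 (`N#Cc1ccc(OCc2nnc(-c3ccc(F)cc3)o2)cc1F`) carries fluoro in place of methoxy on an aromatic carbon, para to a large group (fluoro in place of methoxy on an aromatic carbon). Among the measured compounds shown here, no step between measured compounds shows this change, and compound 1 and compound 2 differ in more than one place. The estimated step of a 1.1-fold lower number from compound 2 to compound 3 (0.06 log units; within the scatter) is expected to stay within the scatter, with no firm direction. Compound 3 is estimated at 40000 nM with an expected range from 15000 nM to 100000 nM in this assay overall.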

Compound 3, half-maximal inhibitory concentration: 25100 nM
Compound 3: middle estimate off by 1.6-fold (0.20 log units), on the high side; the range from low to high includes it.
By their numbers in this assay, from the lowest: compounds 3, 1 and 2 (each within the scatter of the next).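

In this assay the step of a 1.8-fold lower number from compound 2 to compound 3 (0.26 log units; within the scatter) is the only one in the series between compounds that differ in one place. Among the compounds shown here, it gives the first direct reading of 4-methoxyphenyl to 4-fluorophenyl, on an aromatic carbon para to a large group. On this single pair, fluoro and methoxy at this position cannot be told apart on this read-out.

Going by these compounds, whether an amine or a carboxylic acid at this position would give a step beyond the scatter remains open. Nothing available accounts for the step between these two compounds.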